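The compounds below may be only part of what the source reports. "The series", "measured", "known", "first", "only" and "open" are said of these compounds alone.

Among the compounds with values here, in a functional assay on HCT-116 cells (Homo sapiens) for antiproliferative activity, read by MTT assay, with a stated time of 72 h (on this read-out higher numbers stand for weaker inhibition and lower numbers for stronger inhibition), compound 1 `NC1=NC2(CCOCC2)N(OCCCOc2ccccc2Cl)C(N)=N1` gives 70 nM, the highest of the three numbers so far and so the weakest inhibition in this small set. Compound 2 `NC1=NC2(CCSCC2)N(OCCCOc2cc(Cl)c(Cl)cc2Cl)C(N)=N1` gives 1 nM and compound 3 `NC1=NC2(CCSCC2)N(OCCCOc2ccccc2Br)C(N)=N1` gives 1 nM, both lower than compound 1 by more than the scatter.

Compound 4 `NC1=NC2(CCOCC2)N(OCCCOc2cccc(Cl)c2)C(N)=N1` is related to compound 1 by 3-chlorophenyl in place of 2-chlorophenyl on an oxygen on a saturated carbon. The two have the same atoms, joined differently: 3-chlorophenyl in place of 2-chlorophenyl on an oxygen on a saturated carbon, with the rest of the structure unchanged.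

Within the data shown here, one measured step bears on this place: no change at the digits printed from compound 2 to compound 3 (within the scatter), an exchange of 2-bromophenyl for 2,4,5-trichlorophenyl that stays within the scatter. That exchange alters the aryl group more heavily than the present change does, yet no shift is seen. Among the measured compounds shown here, it is only a single step, however, and it was measured at the low end of the numbers. For the measured compounds named here, no measured pair moves a chlorine around the ring, so the range is kept wide.

No shift beyond the scatter is therefore expected in this assay, in either direction. The expected step is no change at the digits printed from compound 1 to compound 4 (within the scatter). For compound 4 the estimated value is 70 nM, with an expected range of 20 nM to 250 nM.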

Compound 4, half-maximal inhibitory concentration: 120 nM
Compound 4: the middle estimate sits 1.7-fold (0.23 log units) below what was measured; the measured number falls inside the stated range.
By their numbers in this assay, from the lowest: compounds 2 and 3 (each within the scatter of the next); then compounds 1 and 4 (each within the scatter of the next).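

In this assay, 3-chlorophenyl in place of 2-chlorophenyl on an oxygen on a saturated carbon gives a 1.7-fold higher number from compound 1 to compound 4 (0.23 log units; within the scatter), so moving the chlorine on this aryl group, with the atoms unchanged, has no effect that can be told from the scatter. The earlier step, no change at the digits printed from compound 2 to compound 3 (within the scatter), exchanged both the halogen and the substitution of the aryl group on the other core at the low end of the numbers, whereas this step shows tolerance at this position on the core of compound 1, at the higher end of the numbers, and neither of the two steps goes against that tolerance. No measurement shown gives a reason for this tolerance on the aryl group.

Compounds 1 and 4 share one core and compounds 2 and 3 another, and no pair shown links the two cores through a single change, so what separates the two groups of values remains unassigned. Also open, on these data alone, is whether the tolerance extends beyond halogens on the aryl group, for instance to an amine or a carboxylic acid there, or to a longer chain leading to the aryl ether.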